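The compounds below may be only part of what the source reports. "The series", "measured", "known", "first", "only" and "open" are said of these compounds alone.

Notes on the series in an assay on isolated protein for inhibition of alkaline phosphatase, tissue-nonspecific isozyme (Homo sapiens); on this read-out higher numbers stand for weaker inhibition and lower numbers for stronger inhibition. Compound 1, `COc1ccc(C(F)(F)F)cc1S(=O)(=O)Nc1cccnc1`, gives 183 nM. Compound 2, `COc1ccc(Br)cc1S(=O)(=O)Nc1cccnc1`, gives 43 nM. For the measured compounds named here, the one measured step, a 4.3-fold lower number from compound 1 to compound 2 (0.63 log units; beyond the scatter), is bromo in place of trifluoromethyl on an aromatic carbon. Going by the values given here, on these two numbers compound 2 stands at the lower one, with compound 1 the only neighbour.

Compound 3, `COc1ccc(C#N)cc1S(=O)(=O)Nc1cccnc1`, is the next case. The change from compound 2 is cyano in place of bromo on an aromatic carbon. Among the compounds with values here, the only step that bears on it is a 4.3-fold lower number from compound 1 to compound 2 (0.63 log units; beyond the scatter), a swap at an aromatic carbon on the same core; it shows that such a swap can move this assay by a modest amount in either direction. Within the data shown here, a step of similar size, probably towards a higher number, is therefore expected, though no number measured so far fixes its direction. The estimate for compound 3 is 100 nM, with a range from 35 nM to 300 nM, meaning an expected step of a 2.3-fold higher number from compound 2 to compound 3 (0.37 log units; beyond the scatter).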

Compound 3, half-maximal inhibitory concentration: 322 nM
Beside the measured number, compound 3's estimate is 3.2-fold (0.51 log units) below it; the measured number lies above the stated range.
By their numbers in this assay, from the lowest: compound 2; then compounds 1 and 3 (each within the scatter of the next).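

Cyano in place of bromo on this aromatic carbon, para to a methoxy group, gives a 7.5-fold higher number from compound 2 to compound 3 (0.87 log units; beyond the scatter) in this assay and is a larger move than the earlier swap at the same carbon. Cyano in place of trifluoromethyl gives a 1.8-fold higher number from compound 1 to compound 3 (0.25 log units; within the scatter) and so does not separate those two groups, which leaves bromo as the only one of the three set apart here, with the lowest number on the shared core. No measurement on hand accounts for this difference among the three groups.

Going by these compounds, whether the low number belongs to bromo alone or extends to chloro or iodo remains open. Also open, on these data alone, is how this carbon responds to an amine, a carboxylic acid or a longer chain such as ethoxymethyl.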